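The compounds below may be only part of what the source reports. "The series", "measured", "known", "first", "only" and "open" are said of these compounds alone.

Three compounds have so far been measured in an assay on isolated protein for inhibition of Amine oxidase [flavin-containing] B (Homo sapiens), read by Amplex Red, with a stated time of 15 min; on this read-out lower numbers stand for stronger inhibition and higher numbers for weaker inhibition:
compound 1 `CC(=O)c1ccc(OCc2ccccc2[N+](=O)[O-])cc1`: 284 nM
compound 2 `CC(=O)c1ccc(OCc2cc(F)c(F)c(F)c2)cc1`: 84.1 nM
compound 3 `CC(=O)c1cccc(OCc2cccc(F)c2)c1`: 193 nM

Among these three numbers compound 3 gives the second highest. Its nearest neighbour is compound 1, whose value lies within the usual scatter of that of compound 3, so no order between the two can be drawn. Compound 2 stands furthest away, with a number that is lower beyond the scatter. Compound 4 `CC(=O)c1cccc(OCc2cccc(Cl)c2)c1` has not yet been measured in this assay. It differs from compound 3 in one place: chloro in place of fluoro on an aromatic carbon. Among the compounds with values here, no measured pair shows the effect of this exchange, so the expectation rests on compound 3 alone. A step of modest size, towards a lower number or none beyond the scatter, is expected. The estimated step from compound 3 to compound 4 is a 1.6-fold lower number from compound 3 to compound 4 (0.21 log units; within the scatter). The expected value for compound 4 is 120 nM, with a range from 50 nM to 300 nM.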

Compound 4, half-maximal inhibitory concentration: 34.2 nM
Compound 4: middle estimate off by 3.5-fold (0.55 log units), on the high side, outside the stated range (below it).
By their numbers in this assay, from the lowest: compound 4; then compound 2; then compounds 3 and 1 (each within the scatter of the next).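

In this assay, chloro in place of fluoro on an aromatic carbon, meta to a large group, gives a 5.6-fold lower number from compound 3 to compound 4 (0.75 log units; beyond the scatter), a step beyond the usual scatter. Within the data shown here, this is the first comparison here of compounds that differ in one place, and it shows that the read-out at this position depends on which of these two halogens is present. Nothing measured here accounts for the size of this step. The compounds shown leave open how a bromo, methyl or methoxy group would compare at this position. They also leave open whether the same exchange gives a similar step elsewhere on the shared core.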